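This account rests on a few compounds, and the source may have more. Where it says the series, first, only, none or still open, it means among the compounds named here.

Measured compounds in a functional assay on the whole organism (strain Wistar) for inhibition, with Rattus norvegicus as the target, read by paw edema, with stated times of 60 min and 4 h, at a dose of 100 mg/kg by the oral route; a lower number here means less inhibition, a higher number more inhibition at the dose given (going by the name of the read-out):
compound 1 `CCCCNC(=O)CC1CCc2cc(OC)c(OC)cc21` gives 25%
compound 2 `CCCCCCNC(=O)CC1CCc2cc(OC)c(OC)cc21` gives 42.1%
compound 3 `COc1cc2c(cc1OC)C(CC(=O)N1CCCC1)CC2` gives 24.2%

Compound 3 has the lowest number of the three, but its value sits within the scatter of compound 1, so the two cannot be ordered; only compound 2 stands apart, a number 17.9 percentage points lower from compound 2 to compound 3 (beyond the scatter). Against compound 1 the exchange of the open chain for the ring gives a number 0.8 percentage points lower from compound 1 to compound 3 (within the scatter), whereas lengthening the chain gives a number 17.1 percentage points higher from compound 1 to compound 2 (beyond the scatter).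

Compound 4 `COc1cc2c(cc1OC)C(CC(=O)N1CCOCC1)CC2` is not yet measured. morpholin-4-yl in place of pyrrolidin-1-yl on a carbonyl carbon The ring stays on the carbonyl carbon; only its size and the oxygen in it change. Among the measured compounds shown here, no measured step touches a morpholin-4-yl group, so the nearest guidance is the pair of amide variations around compound 3: the ring amide and the short chain amide lie within scatter of each other, and only the long chain amide rose beyond it. An exchange between two ring amides is therefore expected to move the number little, if at all, in this assay, with no direction that the shown steps support beyond the scatter.

Compound 4 is estimated at 22%, within 8% to 38%, a step of a number 2.2 percentage points lower from compound 3 to compound 4 (within the scatter) that is expected to stay within the scatter.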

Compound 4, a percentage reported as inhibition, in the whole organism at one dose (the size of the read-out at that dose, not a potency): 13.3%
Compound 4: middle estimate off by 8.7 percentage points, on the high side; the measured number falls inside the stated range.
By their numbers in this assay, from the lowest: compound 4; then compounds 3 and 1 (each within the scatter of the next); then compound 2.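

The exchange of one ring amide for another on the carbonyl carbon is not neutral in this assay: morpholin-4-yl in place of pyrrolidin-1-yl gives a number 10.9 percentage points lower from compound 3 to compound 4 (beyond the scatter) and shows that this position separates two ring amides, whereas the earlier pyrrolidin-1-yl and butylamino pair could not be told apart. The morpholin-4-yl amide also stands apart from both open-chain amides, with a number 11.7 percentage points lower from compound 1 to compound 4 (beyond the scatter) against the butylamino amide and a number 28.8 percentage points lower from compound 2 to compound 4 (beyond the scatter) against the hexylamino amide, which makes compound 4 the lowest of the four at this dose and widens the range reached by changing this one group. No measurement shown gives a reason for the lower number with morpholin-4-yl.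

The step from pyrrolidin-1-yl to morpholin-4-yl changes ring size and adds a ring oxygen together, so the compounds shown cannot assign the drop to either change; a piperidin-1-yl amide on the same carbonyl carbon would separate the two. On these data alone, it also remains open whether the higher number with hexylamino continues with a longer chain such as octylamino.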